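This account rests on a few compounds, and the source may have more. Where it says the series, first, only, none or still open, it means among the compounds named here.

Compound 2 `Cc1noc(-c2ccccc2NCC2=NCCN2)n1` stands at < 5020 nM in a functional assay for activation of Alpha-1D adrenergic receptor (Homo sapiens) (a lower number here means that less compound is needed, a higher number that more compound is needed for the effect), which is a limit of the assay and not a number. Compound 1 `Cc1nc(-c2ccccc2NCC2=NCCN2)co1` gives < 5020 nM in this assay, again only a limit. The step that the two limits leave unreadable from compound 1 to compound 2 cannot be sized because the limit of < 5020 nM in this assay, at which 2 of the 2 values shown sit, holds both values. Compound 3 `c1ccc(-c2ccccc2NCC2=NCCN2)nc1` differs from compound 2 by pyridin-2-yl in place of 3-methyl-1,2,4-oxadiazol-5-yl on an aromatic carbon. Among the measured compounds shown here, no measured step bears on this change in readable size, so its direction is open. The step that the limit leaves unreadable from compound 2 to compound 3 in this assay is expected to stay within the scatter. Compound 3 is estimated at 1500 nM, with a range from 150 nM to 8000 nM.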

Compound 3, half-maximal effective concentration: 41.7 nM
The estimate for compound 3 lay 36-fold (1.56 log units) above the measured number; the measured number lies below the stated range.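

Neither step to compound 3, from compound 1 or from compound 2, can be read in this assay, because both those compounds give only a limit of the assay: the limit of < 5020 nM in this assay, at which 2 of the 3 values shown sit. The compounds shown leave open how large the gap between compound 3 and either of the other two is, and whether compound 1 and compound 2 differ at all.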